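The source may report more compounds than this note shows. Statements on the series, on what has been measured and on what is new or still open speak of the compounds shown alone.

Measured so far:
Compound 1 `CCOC(=O)C(=O)CC(=O)/C=C/c1cn(-c2ccc(Cl)cc2)c2ccccc12` gives "not determined" (no result reported)
Compound 2 `CCOC(=O)C(=O)CC(=O)/C=C/c1cn(Cc2ccc(OC)cc2)c2ccccc12` gives "not determined" (no result reported)
Compound 3 `O=C(/C=C/c1cn(-c2ccc(Cl)cc2)c2ccccc12)CC(=O)C(=O)O` gives 27000 nM
Still open: compound 4 `COc1ccc(Cn2cc(/C=C/C(=O)CC(=O)C(=O)O)c3ccccc32)cc1`

All entries refer to a functional assay on MOLT-4 cells (Homo sapiens) for inhibition, read by MTT assay, with a stated time of 48 h (on this read-out higher numbers stand for weaker inhibition and lower numbers for stronger inhibition), as the single read-out of the series. Among the measured compounds shown here, compound 3 at 27000 nM holds the only number, so it cannot yet be ranked: compound 1 and compound 2 offer no result for comparison.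

The next step leads to compound 4, with 4-methoxybenzyl in place of 4-chlorophenyl on an aromatic nitrogen. 4-methoxybenzyl in place of 4-chlorophenyl on an aromatic nitrogen is the counted difference, two ring bonds from the ring atom that bears a large group.

For the measured compounds named here, the series contains no step between measured compounds, so neither the size nor the direction of this exchange can be read from the data. The working expectation in this assay is therefore no shift beyond the scatter, with compound 3 at 27000 nM as the only anchor. The expected step is a 1.1-fold higher number from compound 3 to compound 4 (0.05 log units; within the scatter) on this reasoning. A single anchor value calls for a wide range. Compound 4 is expected at 30000 nM with an estimated range of 10000 nM to 90000 nM for now.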

Compound 4, half-maximal inhibitory concentration: > 40000 nM
Compound 4: only a limit was reported (the forecaster's own chance of this, stated with the estimate: 15%); at least 1.3-fold (0.12 log units) between middle value and limit.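

In this assay, compound 4 gives > 40000 nM, which is a limit of the assay and not a number. Among the compounds shown here, the exchange of 4-chlorophenyl for 4-methoxybenzyl on the aromatic nitrogen yields the first readable step, an at least 1.4-fold higher number from compound 3 to compound 4 (0.17 log units; that floor lies within the scatter), so this position now has a direction of change on record, although the floor of that step does not by itself separate the two compounds beyond the scatter. The full size of the step stays unread because compound 4 sits at a limit: the limit of > 40000 nM in this assay, at which 1 of the 4 values shown sits.

Steps involving compound 1 and compound 2 cannot be read, so the compounds shown give no comparison of the ethyl ester with the free acid for either group on the nitrogen. Also open, as far as these compounds go, is whether the step belongs to the methoxy group or to the carbon link of the benzyl, which a plain benzyl or a 4-chlorobenzyl on the same nitrogen would help to separate, and how an amine-bearing chain at this position would read in this assay.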